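The source may report more compounds than this note shows. Statements on the series, on what has been measured and on what is new or still open speak of the compounds shown alone.

In a functional assay on Ehrlich cells (Mus musculus) for cytotoxicity, read by trypan blue exclusion, with a stated time of 2 h, tested at 25 ug/mL (on this read-out higher numbers stand for a stronger effect at the one concentration tested and lower numbers for a weaker effect), compound 1 `Cc1ccc(C2C(C#N)=C(N)N(c3ccc(S(N)(=O)=O)cc3)C3=C2CCCC3)cc1` gives 30%, compound 2 `COc1ccccc1C1C(C#N)=C(N)N(c2ccc(S(N)(=O)=O)cc2)C2=C1CCCC2` gives 40%, and compound 3 `COc1ccc2ccccc2c1C1C(C#N)=C(N)N(c2ccc(S(N)(=O)=O)cc2)C2=C1CCCC2` gives 10%. On these numbers compound 2 shows the largest value, but compound 1 stands within the scatter of it, so the two cannot be told apart; compound 3 lies beyond the scatter, with a lower number. Within the data shown here, only one measured pair differs in a single place, 2-methoxyphenyl in place of 4-methylphenyl on a saturated ring carbon, and that step gave a number 10 percentage points higher from compound 1 to compound 2 (within the scatter), which stays within the scatter.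

Compound 4 `Cc1ccc(C2C(C#N)=C(N)N(c3ccc(S(N)(=O)=O)cc3)C3=C2CCCC3)o1` has not yet been measured. It differs from compound 2 in one place: 5-methylfuran-2-yl in place of 2-methoxyphenyl on a saturated ring carbon. Among the measured compounds shown here, no measured pair carries a 5-methylfuran-2-yl group, so the measured steps do not speak directly to this change; the one step on the same saturated ring carbon was within the scatter. The writer therefore expects no step beyond the scatter from compound 2 to compound 4 in this assay, an expected a number 8 percentage points lower from compound 2 to compound 4 (within the scatter). For compound 4 the expected value is 32%, with a range from 12% to 52%.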

Compound 4, a percentage reported as activity, at one concentration (the size of the read-out at that concentration, not a potency): 10%
The estimate for compound 4 lay 22 percentage points above the measured number, outside the stated range (below it).
By their numbers in this assay, from the lowest: compounds 3 and 4 (each within the scatter of the next); then compounds 1 and 2 (each within the scatter of the next).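

Among these compounds, this position is not indifferent to the group it carries: in this assay, 5-methylfuran-2-yl in place of 2-methoxyphenyl gives a number 30 percentage points lower from compound 2 to compound 4 (beyond the scatter), and 5-methylfuran-2-yl in place of 4-methylphenyl gives a number 20 percentage points lower from compound 1 to compound 4 (beyond the scatter), whereas the only step available earlier at this saturated ring carbon stayed within the scatter. Among the compounds shown here, the five-membered aromatic ring with one hetero atom thus marks the first single change here that clearly lowers the number, but this is no rule about ring size, as compound 3, which carries no such ring, also gives 10%. The data shown offer no explanation for this fall.

As far as these compounds go, whether the fall belongs to the furan ring or to its methyl group stays open, as does how a furan-2-yl without the methyl, a thiophen-2-yl or a pyridin-3-yl group would read at this carbon. With one concentration tested, the potency of these compounds also remains unknown.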